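A few compounds are considered here, and "the series" means these few. Any claim that something is new, unique, unknown or untested is made for them only; others in the source may bear on it.

Compound 1 `CC(C)(C)OC(=O)N1CCN(CC(=O)Nc2ccc(C(=O)/C=C/c3cn(Cc4ccc(Br)cc4)nn3)cc2)CC1` and compound 2 `CCCCCCCCn1cc(/C=C/C(=O)c2ccc(NC(=O)CN3CCN(c4ccccc4OC)CC3)cc2)nn1` share a core and differ in several places at once. In a functional assay on HeLa cells (Homo sapiens) for inhibition, read by MTT assay (on this read-out higher numbers stand for weaker inhibition and lower numbers for stronger inhibition), compound 1 gives 18900 nM, and in this assay compound 2 gives 26800 nM; the two numbers lie within the scatter of each other, so compound 2 is not told apart from compound 1 on these values. Compound 3 `CCCCCCCCn1cc(/C=C/C(=O)c2ccc(NC(=O)CN3CCN(C(=O)OC(C)(C)C)CC3)cc2)nn1` is not yet measured; it differs from compound 2 by tert-butoxycarbonyl in place of 2-methoxyphenyl on an amine nitrogen in a ring. Going by the values given here, no comparable single step is available. The same group already stands on compound 1, whose value sits within the scatter of compound 2, so the expected step of a 1.2-fold lower number from compound 2 to compound 3 (0.09 log units; within the scatter) is none beyond the scatter. Compound 3 is expected at 22000 nM, within 8000 nM to 60000 nM.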

Compound 3, half-maximal inhibitory concentration: 32100 nM
For compound 3 the middle estimate is 1.5-fold (0.16 log units) below the measured one; the range from low to high includes it.
By their numbers in this assay, from the lowest: compounds 1, 2 and 3 (each within the scatter of the next).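

On an amine nitrogen in a ring, tert-butoxycarbonyl in place of 2-methoxyphenyl gives a 1.2-fold higher number from compound 2 to compound 3 (0.08 log units; within the scatter) in this assay and so leaves the number unresolved, even though an aromatic ring gives way to a group with no ring. On a saturated chain carbon bound to an aromatic nitrogen, heptyl in place of 4-bromophenyl gives a 1.7-fold higher number from compound 1 to compound 3 (0.23 log units; within the scatter) and likewise separates nothing. No measurement bears on the reason for these results. As far as these compounds go, whether a free secondary amine on that ring nitrogen, or a carboxylic acid at the end of the heptyl chain, would move the number beyond the scatter remains open.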